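Ring configuration swap in a bis-prolinamide series

A few compounds are considered here, and "the series" means these few. Any claim that something is new, unique, unknown or untested is made for them only; others in the source may bear on it.

Three compounds of this series have a number in a physicochemical assay for solubility, in phosphate buffer, measured as kinetic solubility, at pH 7.2 (on this read-out higher numbers stand for higher solubility and lower numbers for lower solubility), so far. Compound 1 `COC(=O)N[C@H](C(=O)N1CCC[C@H]1C(=O)Nc1ccc([C@H]2CC[C@H](c3ccc(NC(=O)[C@@H]4CCCN4C(=O)[C@@H](NC(=O)OC)C(C)C)cc3)N2c2ccc(C(F)(F)F)cc2)cc1)C(C)C` gives 3200 nM. Compound 2 `COC(=O)N[C@H](C(=O)N1CCC[C@H]1C(=O)Nc1ccc([C@H]2CC[C@H](c3ccc(NC(=O)[C@@H]4CCCN4C(=O)[C@@H](NC(=O)OC)C(C)(C)C)cc3)N2c2ccc(F)cc2)cc1)C(C)(C)C` gives 3900 nM. Compound 3 `COC(=O)N[C@H](C(=O)N1CCC[C@H]1C(=O)Nc1ccc([C@@H]2CC[C@@H](c3ccc(NC(=O)[C@@H]4CCCN4C(=O)[C@@H](NC(=O)OC)[C@@H](C)OC)cc3)N2c2ccc(F)cc2)cc1)[C@@H](C)OC` gives 9600 nM, the highest of the three; its nearest neighbour is compound 2, and the gap to it, as to compound 1, lies beyond the usual scatter. Among the measured compounds shown here, no two of the measured compounds differ in only one place, so no single measured step is available to lean on.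

Compound 4 `COC(=O)N[C@H](C(=O)N1CCC[C@H]1C(=O)Nc1ccc([C@H]2CC[C@H](c3ccc(NC(=O)[C@@H]4CCCN4C(=O)[C@@H](NC(=O)OC)[C@@H](C)OC)cc3)N2c2ccc(F)cc2)cc1)[C@@H](C)OC` is the next compound. Against compound 3 the difference is the two compounds have the same atoms and bonds and differ only in configuration as drawn: 2 of 8 stereo elements differ; a stereocentre at a saturated ring carbon is drawn S in compound 3 and R in compound 4; a stereocentre at a saturated ring carbon is drawn S in compound 3 and R in compound 4. Compounds 1 and 2 carry the ring configuration drawn for compound 4, but each also carries a different side chain, so their numbers cannot be read as the effect of the ring configuration alone. With no measured step of this kind in the series, the expectation for this assay is a change within the scatter, if anything a slightly lower number than compound 3. For compound 4 the estimate in this assay is 6000 nM, between 2500 nM and 15000 nM, which means an expected step of a 1.6-fold lower number from compound 3 to compound 4 (0.20 log units; within the scatter).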

Compound 4, solubility: 7700 nM
Estimate against measurement, compound 4: 1.3-fold (0.11 log units) below; the range from low to high includes it.
By their numbers in this assay, from the lowest: compounds 1, 2, 4 and 3 (each within the scatter of the next, the first and the last beyond it).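

In this assay, inverting the two ring stereocentres gives a 1.2-fold lower number from compound 3 to compound 4 (0.10 log units; within the scatter), so at this position and with this side chain the two ring configurations are not separated by this read-out. The earlier compounds shown here could not show this: compound 1 and compound 2 carry the ring configuration of compound 4, but each also has a different side chain, which leaves the configuration and the side chain entangled in their numbers. The pair of compound 3 and compound 4 gives the series its first clean reading of the ring configuration, and that reading holds because of one point: the fact that compounds 3 and 4 differ only in the configuration as drawn.

Going by these compounds, whether the same inversion gives a step of similar size with the side chains of compound 1 or compound 2 stays open, as this is a single pair with a single side chain and a single substituent on the aryl group. Also open, on these data alone, is how the ring configuration behaves in this assay when an amine or a carboxylic acid takes the place of the fluorine on that aryl group.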